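The source may report more compounds than this note shows. Statements on the series, on what has been measured and on what is new or still open speak of the compounds shown alone.

Compound 1 `CNC(=O)c1cc(C(=O)NC2CC2)cn(CC2CCCOC2)c1=O` gives in a physicochemical assay for solubility (on this read-out higher numbers stand for higher solubility and lower numbers for lower solubility), a value that is a limit of the assay, >= 131 ug/mL.
Compound 2 `CNC(=O)c1cc(C(=O)NCCO)cn(Cc2ccccc2)c1=O` gives in this assay a value that is likewise a limit, >= 140 ug/mL.
Compound 3 `CNC(=O)c1cc(C(=O)NC2CC2)cn(Cc2cccc3[nH]ccc23)c1=O` gives in this assay the number 78 ug/mL.

Compound 2 thus stands at a limit of this assay and not at a measured number, as the line the limit of >= 140 ug/mL in this assay, at which 1 of the 3 values shown sits, records; one other compound, compound 1, also sits at a limit, (the limit of >= 131 ug/mL in this assay, at which 1 of the 3 values shown sits). Compound 4 `CNC(=O)c1cc(C(=O)NCCC(C)C)cn(Cc2ccccc2)c1=O` differs from compound 2 in one place: isopropyl in place of hydroxy on a saturated chain carbon, two bonds along the chain from an amide-type nitrogen. Among the compounds with values here, the only measured step, an at least 1.6-fold lower number from compound 1 to compound 3 (0.22 log units; that floor lies within the scatter), exchanges a group on a saturated chain carbon bound to an aromatic nitrogen, a different part of the shared core than the saturated chain carbon two bonds along the chain from an amide-type nitrogen that changes here, so it does not bear on this change directly and gives no measured guide for it. Without such a guide, only a cautious expectation can be made. Compound 4 is expected to give 60 ug/mL, within a range from 15 ug/mL to 160 ug/mL. The step this estimate means, an at least 2.3-fold lower number from compound 2 to compound 4 (0.36 log units; beyond the scatter), is expected to run downward from the limit, though a measured value could still fall within the scatter of it.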

Compound 4, solubility: 10 ug/mL
Compound 4: the middle estimate sits 6.0-fold (0.78 log units) above what was measured; measured number outside the range, below it.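

At this position, the saturated chain carbon two bonds along the chain from an amide-type nitrogen, putting isopropyl in place of hydroxy brings a large change in this assay: an at least 14-fold lower number from compound 2 to compound 4 (1.14 log units; beyond the scatter). The only earlier step, an at least 1.6-fold lower number from compound 1 to compound 3 (0.22 log units; that floor lies within the scatter), changes a different part of the shared core and has a floor within the scatter, which makes this the first step among the compounds shown that clearly lies beyond the scatter. Compound 2 holds a limit and not a measured number, and the true drop may be greater than the step states because of that: the limit of >= 140 ug/mL in this assay, at which 1 of the 4 values shown sits.

The change swaps one oxygen, with its hydrogen-bond donor and acceptor, for three carbons, and the compounds shown cannot tell whether losing the hydroxy or gaining the carbons matters more. On these data alone, whether an amine, a methoxy or a carboxylic acid at this place would give a number closer to that of compound 2 or to that of compound 4 remains open.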